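Methylating the hydroxy of compound 3: expected cytotoxicity

This account rests on a few compounds, and the source may have more. Where it says the series, first, only, none or still open, it means among the compounds named here.

Compound 3 `O=C1/C(=C/c2ccc(O)cc2)CCC/C1=C\c1ccc([N+](=O)[O-])cc1` gives 13000 nM in a functional assay on HSC-3 cells (Homo sapiens) for cytotoxicity (a higher number here means that more compound is tolerated, a lower number that less compound is tolerated), the highest number among the three measured compounds; compound 1 `COc1cc(/C=C2\CCC/C(=C\c3ccc([N+](=O)[O-])cc3)C2=O)ccc1O` gives 5200 nM and compound 2 `O=C1/C(=C/c2ccc(Cl)cc2)CCC/C1=C\c1ccc([N+](=O)[O-])cc1` gives 4600 nM. Compound 4 `COc1ccc(/C=C2\CCC/C(=C\c3ccc([N+](=O)[O-])cc3)C2=O)cc1` differs from compound 3 by methyl in place of hydrogen on an oxygen on an aromatic ring. For the measured compounds named here, two measured steps bear on this change: a 2.5-fold higher number from compound 1 to compound 3 (0.40 log units; beyond the scatter) and a 2.8-fold higher number from compound 2 to compound 3 (0.45 log units; beyond the scatter), both of which ended at the member carrying the free hydroxy, the highest number in the set. Capping that hydroxy in compound 4 is therefore expected to move the number back toward those of compounds 1 and 2, giving a 2.2-fold lower number from compound 3 to compound 4 (0.34 log units; beyond the scatter). Compound 4 is accordingly estimated at 6000 nM in this assay, with a range of 3000 nM to 13000 nM.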

Compound 4, half-maximal cytotoxic concentration: > 400000 nM
Compound 4: only a limit was reported; the forecaster's own chance of this, stated with the estimate: 5%; middle value at least 66-fold (1.82 log units) from the limit.
By their numbers in this assay, from the lowest: compounds 2 and 1 (each within the scatter of the next); then compound 3. At a limit, above all of these: compound 4.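

In this assay compound 4 stands only as a limit: the limit of > 400000 nM in this assay, at which 1 of the 4 values shown sits. Methyl on the oxygen on the aromatic ring gives an at least 30-fold higher number from compound 3 to compound 4 (1.48 log units; beyond the scatter), so capping this hydroxy moves the number much further than any step among compounds 1, 2 and 3 did. The 4-methoxyphenyl compound also separates from the other two, with an at least 86-fold higher number from compound 2 to compound 4 (1.93 log units; beyond the scatter) and an at least 76-fold higher number from compound 1 to compound 4 (1.88 log units; beyond the scatter).

From the compounds shown here alone, whether ethoxy or an amine on that aromatic carbon would behave like methoxy remains open. Going by these compounds, the full size of these steps also remains open, since only their lower bounds can be read.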